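The compounds below may be only part of what the source reports. "The series", "measured", "known", "first", "only" and "open" are said of these compounds alone.

Measured so far in a physicochemical assay for solubility; a lower number here means a less soluble compound, a higher number a more soluble compound:
- Compound 1 `O=C(O)c1ccc(C(=O)/C(=C\c2ccc(F)c([N+](=O)[O-])c2)S(=O)(=O)Cc2ccc(Br)cc2)cc1`: < 1000 ug/mL, a limit of the assay.
- Compound 2 `O=C(O)c1ccc(C(=O)/C(=C\c2ccc(F)c([N+](=O)[O-])c2)[S+]([O-])Cc2ccc(Br)cc2)cc1`: < 1000 ug/mL, also a limit of the assay.

Compound 2 thus has no exact number and stands at the limit of < 1000 ug/mL in this assay, at which 2 of the 2 values shown sit. Compound 3 `O=C(O)c1ccc(C(=O)/C(=C\c2ccc(F)c([N+](=O)[O-])c2)SCc2ccc(Cl)cc2)cc1` differs from it in one group: a group of 9 heavy atoms (7 carbon, 1 sulfur, 1 chlorine; one six-membered aromatic ring of carbon only) in place of a group of 10 heavy atoms (7 carbon, 1 oxygen, 1 sulfur, 1 bromine; one six-membered aromatic ring of carbon only), on a double-bonded chain carbon bound to a carbonyl carbon and a double-bonded chain carbon. Within the data shown here, one measured step bears on this change, a step that the two limits leave unreadable from compound 1 to compound 2, made on the same double-bonded chain carbon. Its size cannot be read, so it gives no measure of how far a change there moves the result in this assay. No step beyond the scatter is therefore expected, in either direction, and another limit is the likeliest reading. The expected value for compound 3 is 500 ug/mL, with an estimated range of 100 ug/mL to 1000 ug/mL. This amounts to an expected step that the limit leaves unreadable from compound 2 to compound 3.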

Compound 3, solubility: < 1000 ug/mL
Compound 3: a limit, no number; the forecaster's own chance of this, stated with the estimate: 85%; the middle value lies beyond the limit too.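

Compound 3 gives only a limit in this assay, so no step among compound 1, compound 2 and compound 3 can be read: the limit of < 1000 ug/mL in this assay, at which 3 of the 3 values shown sit.

The compounds shown leave open the exact value of each one in this assay, and whether changing the group on the double-bonded chain carbon moves the result at all.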